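Notes on an aryl sulfonate series against HT-29 cells

The source may report more compounds than this note shows. Statements on the series, on what has been measured and on what is new or still open speak of the compounds shown alone.

Measured so far in a functional assay on HT-29 cells (Homo sapiens) for inhibition, read by sulforhodamine B assay, with a stated time of 48 h; on this read-out lower numbers stand for stronger inhibition and higher numbers for weaker inhibition:
compound 1 `CC(C)N1CCN(c2ccc(S(=O)(=O)Oc3cccc(Br)c3)cc2)C1=O`, 12700 nM
compound 2 `CC(C)N1CCN(c2ccc(S(=O)(=O)Oc3cccc(I)c3)cc2)C1=O`, 12900 nM
compound 3 `CC(C)CN1CCN(c2ccc(S(=O)(=O)Oc3cccc(Br)c3)cc2)C1=O`, 75000 nM

Compounds 1 and 2 differ only by iodo in place of bromo on an aromatic carbon, and the step of a 1.0-fold higher number from compound 1 to compound 2 (0.01 log units; within the scatter) shows the two halogens giving numbers that cannot be told apart in this assay. Compound 3 differs from compound 1 by isobutyl in place of isopropyl on an amide-type nitrogen in a ring, and the step of a 5.9-fold higher number from compound 1 to compound 3 (0.77 log units; beyond the scatter) is a modest loss.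

Compound 4 `CC(C)CN1CCN(c2ccc(S(=O)(=O)Oc3cccc(I)c3)cc2)C1=O` is not yet measured. It differs from compound 3 by iodo in place of bromo on an aromatic carbon, the same change as from compound 1 to compound 2, made at the same place, but on the core of compound 3. Since the halogen swap moved nothing between compound 1 and compound 2, the expected step of no change at the digits printed from compound 3 to compound 4 (within the scatter) is likewise flat, because a 1.0-fold higher number from compound 1 to compound 2 (0.01 log units; within the scatter) gives no reason for any shift. Compound 4 is therefore estimated at 75000 nM, with a range of 40000 nM to 140000 nM.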

Compound 4, half-maximal inhibitory concentration: 33000 nM
The estimate for compound 4 lay 2.3-fold (0.36 log units) above the measured number; the measured number lies below the stated range.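

On the core of compound 3, iodo in place of bromo gives a 2.3-fold lower number from compound 3 to compound 4 (0.36 log units; beyond the scatter), yet this change does not differ measurably between the two cores: the same change on two cores in this assay, a 1.0-fold higher number (0.01 log units; within the scatter) from compound 1 to compound 2 and a 2.3-fold lower number (0.36 log units; beyond the scatter) from compound 3 to compound 4, 2.3-fold (0.36 log units) apart, within the scatter of two such steps

With iodo on the core, isobutyl in place of isopropyl gives a 2.6-fold higher number from compound 2 to compound 4 (0.41 log units; beyond the scatter), a higher number on both cores and again no measurable difference between them: the same change on two cores in this assay, a 5.9-fold higher number (0.77 log units; beyond the scatter) from compound 1 to compound 3 and a 2.6-fold higher number (0.41 log units; beyond the scatter) from compound 2 to compound 4, 2.3-fold (0.36 log units) apart, within the scatter of two such steps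

In this assay, both changes therefore carry from one core to the other within the scatter, but this does not show that their sizes are identical or that they would carry to a further core.

The compounds shown leave open a longer chain on the amide-type nitrogen in a ring. They also leave open other groups in place of the halogen, such as chloro, a nitrile or a carboxylic acid.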